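A few compounds are considered here, and "the series" means these few. Any claim that something is new, unique, unknown or untested is made for them only; others in the source may bear on it.

Values in an ADME assay on Huh-7 cells (Homo sapiens) for cytotoxicity, with a stated time of 72 h; a higher number here means that more compound is tolerated, a lower number that less compound is tolerated:
- compound 1 `COC(=O)CCCC(=O)n1c(=O)c(C)cn([C@@H]2O[C@H](CO[Si](C)(C)C(C)(C)C)[C@@]3(OS(=O)(=O)C=C3N)[C@H]2O[Si](C)(C)C(C)(C)C)c1=O`: > 100000 nM
- compound 2 `Cc1cn([C@@H]2O[C@H](CO[Si](C)(C)C(C)(C)C)[C@@]3(OS(=O)(=O)C=C3N)[C@H]2O[Si](C)(C)C(C)(C)C)c(=O)n(C(=O)CCCC(N)=O)c1=O`: > 100000 nM
- compound 3 `CNC(=O)CCCC(=O)n1c(=O)c(C)cn([C@@H]2O[C@H](CO[Si](C)(C)C(C)(C)C)[C@@]3(OS(=O)(=O)C=C3N)[C@H]2O[Si](C)(C)C(C)(C)C)c1=O`: > 100000 nM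

Each of these entries is a limit and not a number. Compound 3 therefore has no exact position in the series, and the same applies to the other two compounds: the limit of > 100000 nM in this assay, at which 3 of the 3 values shown sit.

Compound 4 `Cc1cn([C@@H]2O[C@H](CO[Si](C)(C)C(C)(C)C)[C@@]3(OS(=O)(=O)C=C3N)[C@H]2O[Si](C)(C)C(C)(C)C)c(=O)n(C(=O)CCCC(=O)N(C)C)c1=O` differs from compound 3 at one place: methyl in place of hydrogen on an amide-type nitrogen. In words, this is methyl in place of hydrogen on an amide-type nitrogen, or methylcarbamoyl to dimethylcarbamoyl.

Among the compounds with values here, the closest precedent is the same replacement on the primary amide, a step that the two limits leave unreadable from compound 2 to compound 3. The two changes on the carbonyl carbon are less direct precedents: a step that the two limits leave unreadable from compound 1 to compound 2 and a step that the two limits leave unreadable from compound 1 to compound 3. None of the three gives a usable size, so no direction can be taken from them. Since all three compounds end at the same limit, no step beyond the usual scatter is expected in this assay, and the assay will most likely report a limit again.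

The expected change is a number no higher from compound 3 to compound 4 (the limit leaves the size open).

For compound 4 the estimate is 100000 nM, with an expected range of 50000 nM to 200000 nM.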

Compound 4, half-maximal cytotoxic concentration: > 100000 nM
Compound 4: a limit, no number; the forecaster's own chance of this, stated with the estimate: 90%; the middle value sits exactly at the limit.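

In this assay compound 4 gives > 100000 nM as a limit and not a number. Within the data shown here, no step between compound 4 and compound 1, compound 2 or compound 3 can be read. The compounds shown leave open how far any of the four lies from that limit.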